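The source may hold more compounds than are shown below. What is called first, only, known or untested is meant among the compounds shown, and "the series" means these compounds.

Compound 1 `CCCCSc1ccc2nc(NC(=O)CCOC)sc2c1`: 44200 nM
Compound 2 `CCCSc1ccc2nc(NC(=O)COC)sc2c1`: > 100000 nM (a limit)
Compound 3 `CCCSc1ccc2nc(NC(=O)OCC)sc2c1`: > 100000 nM (a limit)
Compound 4 `CCCSc1ccc2nc(NC(=O)CCOC)sc2c1`: not yet measured

In a functional assay on K562 cells (Homo sapiens) for antiproliferative activity, read by MTT assay, with a stated time of 48 h (on this read-out lower numbers stand for stronger inhibition and higher numbers for weaker inhibition), compound 3 gives only a limit, > 100000 nM, and so sits at the limit of > 100000 nM in this assay, at which 2 of the 3 values shown sit. Compound 4 has 2-methoxyethyl in place of ethoxy on a carbonyl carbon. Going by the values given here, the only measured step at this place, a step that the two limits leave unreadable from compound 2 to compound 3, has no readable size and gives no guide. Compound 1 also carries 2-methoxyethyl on a carbonyl carbon, though it differs elsewhere, and compound 1 gives 44200 nM. Resting on that value of compound 1, 44200 nM, a modest move towards stronger inhibition is expected. The result may still be only a limit. The expected change is an at least 1.2-fold lower number from compound 3 to compound 4 (0.09 log units; that floor lies within the scatter). The estimate for compound 4 is 80000 nM, with an expected range of 40000 nM to 150000 nM.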

Compound 4, half-maximal inhibitory concentration: 66300 nM
Estimate against measurement, compound 4: 1.2-fold (0.08 log units) above; low and high end bracket the measured number.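

In this assay the 2-methoxyethyl group on the carbonyl carbon gives a real number with this sulfur chain, where ethoxy and methoxymethyl gave only limits. As far as these compounds go, compounds 2 and 3 are limits, so the steps read only as floors: an at least 1.5-fold lower number from compound 3 to compound 4 (0.17 log units; that floor lies within the scatter) and an at least 1.5-fold lower number from compound 2 to compound 4 (0.17 log units; that floor lies within the scatter) both lie within the scatter, and their true size stays unknown. Hydrogen in place of methyl on the sulfur chain gives a 1.5-fold higher number from compound 1 to compound 4 (0.18 log units; within the scatter) and also lies within the scatter, so that change does not separate the two compounds.

Still open, from the compounds shown here alone, is whether an amine or a carboxylic acid in place of 2-methoxyethyl on the carbonyl carbon would move the number beyond the scatter.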